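Oxan-4-yl for 4-cyanophenyl: cytotoxicity notes

The compounds below may be only part of what the source reports. "The series", "measured", "known", "first", "only" and "open" are said of these compounds alone.

Compound 1 `COc1nc(-c2ccncc2)ccc1[C@@H](c1ccccc1)[C@@](O)(CCN(C)C)c1cccc2ccccc12`: > 50 ug/mL
Compound 2 `COc1nc(-c2ccc(C#N)cc2)ccc1[C@@H](c1ccccc1)[C@@](O)(CCN(C)C)c1cccc2ccccc12`: > 50 ug/mL
Compound 3 `COc1nc(C2CCOCC2)ccc1[C@@H](c1ccccc1)[C@@](O)(CCN(C)C)c1cccc2ccccc12`: not yet measured

In a toxicity assay on Vero cells (Chlorocebus sabaeus) for cytotoxicity (on this read-out lower numbers stand for higher toxicity in this test and higher numbers for lower toxicity in this test), compound 2 stands at > 50 ug/mL, which is a limit of the assay and not a number. Compound 1 gives > 50 ug/mL, which is also a limit. Among the compounds with values here, the series so far therefore offers only (the limit of > 50 ug/mL in this assay, at which 2 of the 2 values shown sit).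

The change now followed is oxan-4-yl in place of 4-cyanophenyl on an aromatic carbon. In words, oxan-4-yl comes in place of 4-cyanophenyl on an aromatic carbon of a six-membered aromatic ring with 1 nitrogen. Within the data shown here, the one measured step that bears on it is a step that the two limits leave unreadable from compound 1 to compound 2, with 4-cyanophenyl in place of pyridin-4-yl on an aromatic carbon. That step gives no size to carry over. No step beyond the scatter is expected in this assay, and no direction can be assigned. Another limit reading is the most likely result. The estimated step is a step that the limit leaves unreadable from compound 2 to compound 3. For compound 3 the expected value is 60 ug/mL, with an estimated range from 25 ug/mL to 150 ug/mL.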

Compound 3, half-maximal cytotoxic concentration: > 50 ug/mL
Compound 3 was reported as a limit; the forecaster's own chance of this, stated with the estimate: 80%; the middle value lies beyond the limit too.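

In this assay compound 3 gives > 50 ug/mL, which is a limit of the assay and not a number. Within the data shown here, no step among compound 1, compound 2 and compound 3 can be read: the limit of > 50 ug/mL in this assay, at which 3 of the 3 values shown sit. The compounds shown leave open how far apart their true cytotoxic concentrations lie, and which change on the shared core would give a measurable value.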